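This account rests on a few compounds, and the source may have more. Where it says the series, first, only, none or still open, it means among the compounds named here.

Working notes on the series. Compound 1 `Cc1cc(=O)c2c(O)cc(OCc3ccco3)c([C@H]3CCN(C)C[C@H]3O)c2o1` gives 6% in a functional assay on MCF7 cells (Homo sapiens) for inhibition, read by MTT assay, with a stated time of 48 h, tested at 10 uM; a lower number here means less inhibition of growth, a higher number more inhibition of growth at the concentration tested. Compound 2 `Cc1cc(=O)c2c(O)c(CN3CCC(N4CCCCC4)CC3)c(O)c([C@H]3CCN(C)C[C@H]3O)c2o1` gives 25% in this assay. Within the data shown here, of the two numbers recorded so far compound 2 stands highest, and its only neighbour, compound 1, sits lower by a gap beyond the usual scatter of this kind of measurement. Among the measured compounds shown here, no pair that differs in a single place has been measured, so the two values can only be set side by side as they stand, and nothing can be read from them about any one structural change.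

Compound 3 `Cc1cc(=O)c2c(O)c(CN3CCCCC3)c(O)c([C@H]3CCN(C)C[C@H]3O)c2o1` is the next member to go into this assay. It differs from compound 2 in one place: hydrogen in place of piperidin-1-yl on a saturated ring carbon. The piperidin-1-yl group is taken away and the rest of compound 2 is kept.

Without a measured single-site step to lean on, the step is expected to be small, toward less inhibition, and not clearly beyond the scatter, that is a number 7 percentage points lower from compound 2 to compound 3 (within the scatter). Compound 3 is estimated at 18% in this assay, within a range from 5% to 33%.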

Compound 3, percent growth inhibition at one concentration: 15%
Compound 3: the middle estimate sits 3 percentage points above what was measured; the measured number falls inside the stated range.
By their numbers in this assay, from the lowest: compounds 1, 3 and 2 (each within the scatter of the next, the first and the last beyond it).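

Among these compounds, this is the first single-site step: in this assay, hydrogen in place of piperidin-1-yl on a saturated ring carbon, three ring bonds from the ring nitrogen, gives a number 10 percentage points lower from compound 2 to compound 3 (within the scatter). The whole piperidin-1-yl group, with its six-membered non-aromatic ring, can therefore leave this position without a change that this measurement can separate from scatter, so compound 2 and compound 3 cannot be ranked here and the piperidin-1-yl group is not shown to matter for growth inhibition at the concentration tested. No measured evidence bears on this step, and the result stays an observation without an explanation.

A single pair leaves open whether this position tolerates other groups in general, since only piperidin-1-yl and hydrogen have been compared on this ring carbon. A dimethylamino group, a carboxylic acid or a longer chain such as n-butyl at the same place could still give a step beyond the scatter, and the present values do not indicate in which direction any of these would go.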